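The source may hold more compounds than are shown below. What is called first, only, known or untested is meant among the compounds shown, and "the series" means these compounds.

Among the compounds with values here, in a functional assay on PC-3 cells (Homo sapiens) for antiproliferative activity, read by CCK-8 assay, with a stated time of 6 days (on this read-out higher numbers stand for weaker inhibition and lower numbers for stronger inhibition), compound 1 `CCN(c1ccc(C#N)c(Cl)c1)c1cc(-c2ccncc2)ccc1C` gives 3580 nM, and this is the only number available. The other compound on record, compound 2 `N#Cc1ccc(N2CCc3cc(-c4cnc5ccccc5c4)ccc32)cc1C(F)(F)F`, has the entry "not determined" (no result reported) in this assay, so it offers no comparison. Compound 1 therefore stands alone, and nothing yet shows whether its value is good or poor for compounds of this kind.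

Compound 3 `CCN(c1ccc(C#N)c(Cl)c1)c1cc(-c2ccnn2C)ccc1C` keeps the core of compound 1 and alters a single group: 1-methyl-1H-pyrazol-5-yl in place of pyridin-4-yl on an aromatic carbon. A 1-methyl-1H-pyrazol-5-yl takes the place of pyridin-4-yl on an aromatic carbon, at the spot para to a methyl group. One aromatic ring is thus exchanged for another, while the rest of the molecule stays the same.

Within the data shown here, no measured pair shows what a change at this spot does in this assay. With no evidence for either direction, the expectation is a shift no larger than the usual scatter. The expected change is a 1.0-fold lower number from compound 1 to compound 3 (0.01 log units; within the scatter), and the data give no firm basis for its sign. The estimated value for compound 3 is 3500 nM, with an expected range of 900 nM to 13000 nM.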

Compound 3, half-maximal inhibitory concentration: 7290 nM
Beside the measured number, compound 3's estimate is 2.1-fold (0.32 log units) below it; measured number inside the range.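

In this assay, putting 1-methyl-1H-pyrazol-5-yl in place of pyridin-4-yl gives a 2.0-fold higher number from compound 1 to compound 3 (0.31 log units; beyond the scatter), which means weaker inhibition. This first measured pair shows that the aromatic carbon para to a methyl group is not indifferent to the ring it carries, although the step is modest and lies only just beyond the usual scatter of repeated measurements. No separate measurement shows why the number moves with this exchange of one aromatic ring for another.

As far as these compounds go, with a single replacement to read at this spot, it remains open whether a plain phenyl ring, a pyrimidin-4-yl ring or a non-aromatic group such as a dimethylamino group would raise the number further or bring it lower than that of compound 1. From the compounds shown here alone, it also remains open whether this step would keep its size and direction if another part of the shared core were changed.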